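Working notes: chloro to hydroxy in the series

The compounds below may be only part of what the source reports. "The series", "measured", "known", "first", "only" and "open" are said of these compounds alone.

Measured in a functional assay on HCT-116 cells (Homo sapiens) for antiproliferative activity, read by MTT assay, with a stated time of 24 h; on this read-out higher numbers stand for weaker inhibition and lower numbers for stronger inhibition
- compound 1 `COc1ccc(C(=O)/C=C/c2ccc([N+](=O)[O-])cc2)c2c1C=CC(C)(C)O2` gives 8880 nM
- compound 2 `COc1ccc(C(=O)/C=C/c2ccccc2)c2c1C=CC(C)(C)O2` gives > 10000 nM as a limit
- compound 3 `COc1ccc(C(=O)/C=C/c2ccc(Cl)cc2)c2c1C=CC(C)(C)O2` gives > 10000 nM as a limit

Compound 3 stands at the limit of > 10000 nM in this assay, at which 2 of the 3 values shown sit, and so offers a limit, not a number, as the starting point. Compound 4 `COc1ccc(C(=O)/C=C/c2ccc(O)cc2)c2c1C=CC(C)(C)O2` carries hydroxy in place of chloro on an aromatic carbon, para to a large group (hydroxy in place of chloro on an aromatic carbon). In other words, 4-chlorophenyl becomes 4-hydroxyphenyl. Among the compounds with values here, no measured step covers hydroxy itself, but three steps at this same place bear on the change. The first is an at least 1.1-fold higher number from compound 1 to compound 2 (0.05 log units; that floor lies within the scatter) and the second is an at least 1.1-fold higher number from compound 1 to compound 3 (0.05 log units; that floor lies within the scatter) while the third is a step that the two limits leave unreadable from compound 2 to compound 3 in the same series. None of them gives a size readable beyond the scatter. Only compound 1 gives a number (8880 nM) and it offers no measured guide to hydroxy. No step beyond the scatter is expected in this assay and no direction can be read from the data. The estimated change is a number no higher from compound 3 to compound 4 (the limit leaves the size open) on this basis. Another limit is the likelier report for compound 4. Compound 4 is expected at 10000 nM with an estimated range of 5000 nM to 25000 nM as the working figure.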

Compound 4, half-maximal inhibitory concentration: > 10000 nM
Compound 4: no number, only a limit; the forecaster's own chance of this, stated with the estimate: 65%; the middle value lies on the limit itself.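

In this assay compound 4 gives > 10000 nM, which is a limit and not a number. The change from 4-chlorophenyl to 4-hydroxyphenyl brings in a hydrogen-bond donor and a hydrogen-bond acceptor at this place, yet hydroxy also yields no number, and the series now reads mostly as a single ceiling: the limit of > 10000 nM in this assay, at which 3 of the 4 values shown sit. Within the data shown here, the one step that can be read is an at least 1.1-fold higher number from compound 1 to compound 4 (0.05 log units; that floor lies within the scatter), and the steps to compound 4 from the two other limit compounds cannot be read.

Among these compounds, compound 1 remains the only compound here with a number, so the data do not tell whether hydrogen, chloro and hydroxy differ from one another in this assay, or how far past the limit any of them lies. As far as these compounds go, how an amine or a carboxylic acid on this aromatic carbon would read stays open, as does whether any group at this place gives a step beyond the scatter.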